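This account rests on a few compounds, and the source may have more. Where it says the series, first, only, none or still open, it means among the compounds named here.

Compound 1 `CNS(=O)(=O)c1ccc(NC(=O)NCc2ccncc2)cc1` is the reference point of this comparison. In an assay on isolated protein for activation of Nicotinamide phosphoribosyltransferase (Homo sapiens) (a higher number here means that more compound is needed for the effect, a lower number that less compound is needed), compound 1 gives 3230 nM, which places it second highest among the three measured numbers. Compound 2 `CCOC(=O)c1ccc(N/C(=N\C#N)NCc2ccncc2)cc1` stands furthest away from it; in this assay compound 2 gives 41400 nM, a far higher number than that of compound 1. Compound 3 `O=C(NCc1ccncc1)Nc1ccc(S(=O)(=O)N2CC3CCC(C2)O3)cc1` is the nearest neighbour; in this assay compound 3 gives 279 nM. Among the compounds with values here, the only step between compounds that differ in one place is a 12-fold lower number from compound 1 to compound 3 (1.06 log units; beyond the scatter), a large step brought about by replacing the small group on the sulfonyl sulfur with a bicyclic one.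

Compound 4 `NS(=O)(=O)c1ccc(NC(=O)NCc2ccncc2)cc1` differs from compound 1 by the change (hydrogen in place of methyl on a sulfonamide nitrogen). Within the data shown here, no measured pair shows this particular change. The step from compound 1 to compound 3 shows that what sits on the sulfonamide nitrogen can shift the number a great deal, but it involved a much larger group entering, not a methyl leaving, so its direction cannot be carried over. With nothing pointing one way or the other, compound 4 is expected to land close to compound 1, with the step of a 1.1-fold lower number from compound 1 to compound 4 (0.03 log units; within the scatter) staying within the scatter. The estimate for compound 4 in this assay is 3000 nM, with a range from 900 nM to 10000 nM.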

Compound 4, half-maximal effective concentration: 14300 nM
The estimate for compound 4 lay 4.8-fold (0.68 log units) below the measured number; measured number outside the range, above it.
By their numbers in this assay, from the lowest: compound 3; then compound 1; then compound 4; then compound 2.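

Hydrogen in place of methyl on the sulfonamide nitrogen brings a 4.4-fold higher number from compound 1 to compound 4 (0.65 log units; beyond the scatter) in this assay, so even the loss of this one small group moves the number beyond the scatter, and the direction of that move is now known. Set against the larger group on the sulfonyl sulfur, the amino compound gives a 51-fold higher number from compound 3 to compound 4 (1.71 log units; beyond the scatter), which is a far bigger step than the removal of the methyl alone. Among these three compounds, which differ only in this place, the number therefore falls in order from amino through methylamino to the bicyclic group of compound 3, and no evidence shown here accounts for this order.

The compounds shown leave open whether an ethyl group or a longer chain on the sulfonamide nitrogen would continue this fall, or whether the order would break somewhere short of the bicyclic group. They also leave open whether a plain piperidine ring on the sulfonyl sulfur would match compound 3, which would tell whether the ring oxygen and the bridge matter at all.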